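Cytotoxicity of alkynyl-substituted analogues in WI-38 cells

A few compounds are considered here, and "the series" means these few. Any claim that something is new, unique, unknown or untested is made for them only; others in the source may bear on it.

Measured compounds:
- compound 1, `CCCCCCCCC#Cc1cn(C/C=C\CN2C(=O)c3ccccc3C2=O)c(=O)[nH]c1=O`: 49000 nM
- compound 2, `CCCCC#Cc1cn(C/C=C/CN2C(=O)c3ccccc3C2=O)c(=O)[nH]c1=O`: 35000 nM
- compound 3, `CCCCCc1ccc(C#Cc2cn(C/C=C/CN3C(=O)c4ccccc4C3=O)c(=O)[nH]c2=O)cc1`: 25000 nM

In an ADME assay on WI-38 cells (Homo sapiens) for cytotoxicity, read by MTT assay, with a stated time of 3 days (on this read-out lower numbers stand for stronger inhibition and higher numbers for weaker inhibition), compound 3 gives the lowest of the three numbers, but its neighbours lie close: compound 2 is the nearest and compound 1 the furthest, and both gaps fall within the scatter, so none of the three can be called more or less cytotoxic than another. The unmeasured compound 4, `CCCCCCCCC#Cc1cn(C/C=C/CN2C(=O)c3ccccc3C2=O)c(=O)[nH]c1=O`, differs from compound 3 in one place: octyl in place of 4-pentylphenyl on a triple-bonded carbon. For the measured compounds named here, the single measured step that bears on this is a 1.4-fold lower number from compound 2 to compound 3 (0.15 log units; within the scatter), which exchanges a chain for the same 4-pentylphenyl group and changes nothing beyond the scatter. Compound 1 also carries octyl on a triple-bonded carbon, though on a differently arranged linker, and its value of 49000 nM sits in the same band as compound 3. Compound 4 is therefore expected to show a 1.4-fold higher number from compound 3 to compound 4 (0.15 log units; within the scatter). The estimated value of compound 4 is 35000 nM, with a range from 15000 nM to 80000 nM.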

Compound 4, half-maximal inhibitory concentration: 53000 nM
For compound 4 the middle estimate is 1.5-fold (0.18 log units) below the measured one; measured number inside the range.
By their numbers in this assay, from the lowest: compounds 3, 2, 1 and 4 (each within the scatter of the next, the first and the last beyond it).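

In this assay, for the compounds shown here, replacing 4-pentylphenyl with octyl on a triple-bonded carbon gives the first step beyond the scatter, though a modest one: a 2.1-fold higher number from compound 3 to compound 4 (0.33 log units; beyond the scatter). Extending the chain from butyl to octyl does not separate the two compounds, with a 1.5-fold higher number from compound 2 to compound 4 (0.18 log units; within the scatter), so the chain compounds stay within the scatter of each other even though compound 3 and compound 4 are set apart. The double bond of the linker, drawn Z or E, also makes no difference beyond the scatter, with a 1.1-fold higher number from compound 1 to compound 4 (0.03 log units; within the scatter), and this comparison tests that double bond alone: the fact that compounds 1 and 4 differ only in the configuration as drawn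

The compounds shown leave open whether the ring or the rest of the 4-pentylphenyl group accounts for the step from octyl. They also leave open how a decyl chain, an amine or a carboxylic acid would read on the same triple-bonded carbon.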